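The source may hold more compounds than are shown below. What is called first, only, known or untested is meant among the compounds shown, and "the series" means these compounds.

Compound 1 `C/C(=C\C(=O)Nc1ccccc1OCCCC(=O)O)c1ccc2c(ccn2C)c1` gives 780 nM in an assay on Prostate gland for inhibition of steroid 5-alpha-reductase (Rattus norvegicus); on this read-out higher numbers stand for weaker inhibition and lower numbers for stronger inhibition. Compound 2 `CCCn1ccc2cc(/C(C)=C/C(=O)Nc3ccccc3OCCCC(=O)O)ccc21` gives 190 nM in this assay. Compound 3 `CCCCn1ccc2cc(/C(C)=C/C(=O)Nc3ccccc3OCCCC(=O)O)ccc21` gives 43 nM in this assay.

Among these three, compound 3 stands lowest, and so is the strongest inhibitor shown: its nearest neighbour is compound 2, with a 4.4-fold lower number from compound 2 to compound 3 (0.65 log units; beyond the scatter), and the furthest is compound 1, with an 18-fold lower number from compound 1 to compound 3 (1.26 log units; beyond the scatter). Each of the measured steps adds carbon to the chain on the aromatic nitrogen, and each lowered the number: a 4.1-fold lower number from compound 1 to compound 2 (0.61 log units; beyond the scatter) and a 4.4-fold lower number from compound 2 to compound 3 (0.65 log units; beyond the scatter) are of similar size.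

Compound 4 `C/C(=C\C(=O)Nc1ccccc1OCCCC(=O)O)c1ccc2c(ccn2CC(C)C)c1` differs from compound 3 by isopropyl in place of propyl on a saturated chain carbon bound to an aromatic nitrogen. The two compounds hold the same atoms, joined differently; the change rearranges the chain into a branch without adding or removing anything. Within the data shown here, none of the measured steps is of that kind, so none bears directly on it. The steps shown say only that the carbon count of this chain matters; they say nothing about its shape. A modest step in this assay in either direction cannot be ruled out, but none beyond the scatter is expected, so the expected step is a 1.4-fold higher number from compound 3 to compound 4 (0.14 log units; within the scatter). Compound 4 is therefore estimated at 60 nM, with a range from 20 nM to 200 nM.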

Compound 4, half-maximal inhibitory concentration: 160 nM
For compound 4 the middle estimate is 2.7-fold (0.43 log units) below the measured one, within the range that was stated.
By their numbers in this assay, from the lowest: compound 3; then compounds 4 and 2 (each within the scatter of the next); then compound 1.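

Carbon count alone does not set the number at this position: butyl and isobutyl hold the same atoms, yet moving to the branched chain gives a step beyond the scatter (a 3.7-fold higher number from compound 3 to compound 4 (0.57 log units; beyond the scatter)), so the shape of the chain matters too. The added methyl that turns the propyl-type chain of compound 2 into the branched chain of compound 4 brings no change beyond the scatter (a 1.2-fold lower number from compound 2 to compound 4 (0.07 log units; within the scatter)), whereas the earlier step that extended the same chain in a straight line did lower the number, which shows that where the added carbon sits decides its effect. Among these compounds, the branched chain still keeps a clear gain over the short chain of the first compound (a 4.9-fold lower number from compound 1 to compound 4 (0.69 log units; beyond the scatter)), and nothing measured here explains why the branch costs what it does.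

The compounds shown leave open whether a longer straight chain, such as pentyl, would lower the number further or whether butyl is already the best length. They also leave open whether a branch placed further out on the chain, as in isopentyl, would cost as much as the isobutyl branch.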